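Compound 2 to Compound 3: Expected Growth Inhibition

The source may hold more compounds than are shown below. What is called first, only, known or untested is meant among the compounds shown, and "the series" means these compounds.

Measured so far:
compound 1, `COc1ccccc1/C=C/C(=O)/C=C/c1ccc(OCc2cn(CCOc3cc(=O)oc4ccccc34)nn2)c(OC)c1`, 11%
compound 2, `COc1ccc(/C=C/C(=O)/C=C/c2ccc(OCc3cn(CCCCCOc4cc(=O)oc5ccccc45)nn3)c(OC)c2)cc1`, "not active" (no number reported)

In a functional assay on PC-3 cells (Homo sapiens) for inhibition, read by sulforhodamine B assay, with a stated time of 48 h, tested at 50 uM (a lower number here means less inhibition of growth, a higher number more inhibition of growth at the concentration tested), compound 1 gives 11%. Compound 2 is reported in this assay only as "not active" (no number reported), with no single number, so it cannot be placed on a scale against compound 1 beyond that both show little inhibition.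

Compound 3, `COc1cc(/C=C/C(=O)/C=C/c2cc(OC)c(OC)c(OC)c2)ccc1OCc1cn(CCCCCOc2cc(=O)oc3ccccc23)nn1`, has not been measured. It differs from compound 2 in one place: 3,4,5-trimethoxyphenyl in place of 4-methoxyphenyl on a double-bonded chain carbon bound to a double-bonded chain carbon. Among the measured compounds shown here, no step between measured compounds is available to size this change. Given that compound 2 is reported as "not active" (no number reported), no step beyond the usual scatter is expected in this assay, in either direction. On that basis compound 3 is estimated to give 10% in this assay, within a range from 0% to 30%.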

Compound 3, percent growth inhibition at one concentration: "not active" (no number reported)
Compound 3: no number reported, so the estimate cannot be set against anything.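

In this assay compound 2 and compound 3 both stand without a number, and no step can be read between them. The compounds shown leave open whether 3,4,5-trimethoxyphenyl in place of 4-methoxyphenyl changes growth inhibition at all. No evidence bears on this result.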